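A Chlorine Pattern Change Across Two Related Pairs

The compounds below may be only part of what the source reports. "The series", "measured", "known", "first", "only" and "open" are said of these compounds alone.

Measured so far:
compound 1 `COc1cccc(/C=C2\CCC/C(=C\c3cccc(Cl)c3Cl)C2=O)c1OC` — > 20000 nM
compound 2 `COc1cccc(/C=C2\CCC/C(=C\c3ccc(Cl)cc3Cl)C2=O)c1OC` — > 20000 nM
compound 3 `COc1ccc(/C=C2\CCC/C(=C\c3cccc(Cl)c3Cl)C2=O)cc1OC` — 14300 nM

In a functional assay on MCF7 cells (Homo sapiens) for cytotoxicity, read by MTT assay, with a stated time of 72 h (a lower number here means a stronger inhibitor, a higher number a weaker inhibitor), compound 1 gives > 20000 nM, which is a limit of the assay and not a number. Compound 2 likewise gives > 20000 nM, again a limit. Going by the values given here, compound 3 is the one compound with an actual number, giving 14300 nM in this assay. The change from compound 1 to compound 2 is 2,4-dichlorophenyl in place of 2,3-dichlorophenyl on a double-bonded chain carbon bound to a double-bonded ring carbon, and the step it made, a step that the two limits leave unreadable from compound 1 to compound 2, cannot be read because both values sit at the limit of > 20000 nM in this assay, at which 2 of the 3 values shown sit. How the core of compound 1 differs from the core of compound 3 is not broken down here.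

Compound 4 `COc1ccc(/C=C2\CCC/C(=C\c3ccc(Cl)cc3Cl)C2=O)cc1OC` has not yet been measured in this assay. It differs from compound 3 by 2,4-dichlorophenyl in place of 2,3-dichlorophenyl on a double-bonded chain carbon bound to a double-bonded ring carbon, the same change that separates compound 1 from compound 2, made at the same place in both pairs. The measured pair gives no readable size for this change, so the expectation for compound 4 rests on compound 3 alone and on the absence of any visible effect from compound 1 to compound 2. The step from compound 3 to compound 4 is therefore estimated as a 1.0-fold higher number from compound 3 to compound 4 (0.02 log units; within the scatter), a step that would stay within the usual scatter. Compound 4 is expected to give about 15000 nM in this assay, with an estimated range from 5000 nM to 40000 nM.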

Compound 4, half-maximal inhibitory concentration: 16200 nM
The estimate for compound 4 lay 1.1-fold (0.03 log units) below the measured number; the measured number falls inside the stated range.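

In this assay, putting 2,4-dichlorophenyl in place of 2,3-dichlorophenyl gives a 1.1-fold higher number from compound 3 to compound 4 (0.05 log units; within the scatter), so on the core of compound 3 the two chlorine patterns cannot be told apart. The same change on the core of compound 1 cannot be read, because both members of that pair give a limit of the assay and not a number: the limit of > 20000 nM in this assay, at which 2 of the 4 values shown sit. The series therefore holds one readable step for this change, which shows that it leaves no effect beyond the scatter on the core of compound 3, but does not show that the change behaves the same way on the core of compound 1.

The compounds shown leave open whether anything other than a rearrangement of the chlorines on this phenyl ring would move the number in this assay, for instance a trifluoromethyl group, a nitrile or an amine in place of a chlorine. Going by these compounds alone, they also leave open how the methoxy groups on the other ring contribute, since no step in which a methoxy group is replaced by a hydroxyl group or a longer alkoxy chain is available here.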